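Moving the methyl group around the aryl ring of compound 2

The source may report more compounds than this note shows. Statements on the series, on what has been measured and on what is new or still open speak of the compounds shown alone.

Three sulfonamides have been measured in an assay on isolated protein for inhibition of alkaline phosphatase, tissue-nonspecific isozyme (Homo sapiens); a lower number here means a stronger inhibitor, a higher number a weaker inhibitor. Compound 1 `COc1cc(Cl)ccc1S(=O)(=O)Nc1cccnc1` gives 4170 nM, compound 3 `COc1ccc(S(=O)(=O)Nc2cccnc2)c(OC)c1` gives 10300 nM, and compound 2 `COc1ccc(Cl)cc1S(=O)(=O)Nc1cncc(-c2ccccc2C)c1` gives 178 nM, the lowest number of the three. Among the compounds with values here, the one single-point step among them, a 2.5-fold higher number from compound 1 to compound 3 (0.39 log units; beyond the scatter), concerns methoxy in place of chloro, which does not touch the change now at hand. Compound 4 `COc1ccc(Cl)cc1S(=O)(=O)Nc1cncc(-c2cccc(C)c2)c1` differs from compound 2 only as follows: 3-methylphenyl in place of 2-methylphenyl on an aromatic carbon. Within the data shown here, no measured pair shows what this rearrangement does, so no step beyond the scatter is expected either way; the number for compound 4 in this assay is estimated at 200 nM, between 70 nM and 600 nM, meaning an expected change of a 1.1-fold higher number from compound 2 to compound 4 (0.05 log units; within the scatter).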

Compound 4, half-maximal inhibitory concentration: 160 nM
The estimate for compound 4 lay 1.3-fold (0.10 log units) above the measured number; measured number inside the range.
By their numbers in this assay, from the lowest: compounds 4 and 2 (each within the scatter of the next); then compound 1; then compound 3.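

In this assay, shifting the methyl group from 2-methylphenyl to 3-methylphenyl gives a 1.1-fold lower number from compound 2 to compound 4 (0.05 log units; within the scatter), so the two placements cannot be told apart on this aryl ring, which sits on an aromatic carbon two atoms from the ring nitrogen. The earlier compounds shown here held no pair that read the place of this methyl. Nothing at hand explains why the two placements match. Still open, going by these compounds, is whether an amine or a carboxylic acid in place of the methyl would keep the number near that of compound 4 at 160 nM.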